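Dichloroacetanilides and one meta substituent swap

The source may report more compounds than this note shows. Statements on the series, on what has been measured and on what is new or still open speak of the compounds shown alone.

Measured compounds:
- Compound 1, `O=C(Nc1ccccc1NC(=O)C(Cl)Cl)C(Cl)Cl`: in a functional assay on BGC-823 cells (Homo sapiens) for antiproliferative activity, read by MTT assay, with a stated time of 72 h (on this read-out higher numbers stand for weaker inhibition and lower numbers for stronger inhibition), compound 1 gives "not determined" (no result reported).
- Compound 2, `O=C(Nc1cccc(I)c1)C(Cl)Cl`: in this assay compound 2 gives 58800 nM.

Among the measured compounds shown here, compound 2 therefore stands as the only compound with a number in this assay, and that number is high. Compound 3, `O=C(Nc1cccc(SC(F)(F)F)c1)C(Cl)Cl`, is not yet measured. It differs from compound 2 by one change: (trifluoromethyl)sulfanyl in place of iodo on an aromatic carbon. For the measured compounds named here, no step between two measured compounds exists here to guide the size of this change, so the expectation rests on compound 2 alone. The step from compound 2 to compound 3 is expected to be a 1.2-fold lower number from compound 2 to compound 3 (0.07 log units; within the scatter), that is, no change beyond the scatter. Compound 3 is estimated at 50000 nM, with a range from 20000 nM to 150000 nM.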

Compound 3, half-maximal inhibitory concentration: 123000 nM
Compound 3: the middle estimate sits 2.5-fold (0.39 log units) below what was measured, within the range that was stated.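

In this assay this aromatic carbon gives its first readable step: (trifluoromethyl)sulfanyl in place of iodo produces a 2.1-fold higher number from compound 2 to compound 3 (0.32 log units; beyond the scatter), a modest weakening beyond the scatter. The change therefore does not improve on the already high number, and the substituent at this position can shift the read-out measurably. No available measurement bears on the reason for this step. On these data alone, what an amine, a carboxylic acid or a longer chain on this carbon would do remains open, and two substituents alone establish no trend.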